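The source may hold more compounds than are shown below. What is called first, only, known or untested is meant among the compounds shown, and "the series" means these compounds.

Of the compounds shown here, three sharing one core have been tested in an ADME assay on L02 cells (Homo sapiens) for cytotoxicity, read by MTT assay; a higher number here means a weaker inhibitor, a lower number a stronger inhibitor. Compound 1 (`C=CCOc1cc(/C=C/C(=O)c2ccc(OC)c3c2OC(C)(C)C=C3)ccc1OC`), with allyl on an oxygen on an aromatic ring, is reported only as a limit, > 20000 nM. Compound 2 (`COc1ccc(/C=C/C(=O)c2ccc(OC)c3c2OC(C)(C)C=C3)cc1OCCCN(C)C`), with 3-(dimethylamino)propyl on that oxygen, gives a true number, 8600 nM. Compound 3 (`CCC(=O)Oc1cc(/C=C/C(=O)c2ccc(OC)c3c2OC(C)(C)C=C3)ccc1OC`), with propanoyl there, is also reported only as a limit, > 10000 nM. Compound 3 therefore has no exact place on the scale.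

Compound 4 (`CCCCC(=O)Oc1cc(/C=C/C(=O)c2ccc(OC)c3c2OC(C)(C)C=C3)ccc1OC`) differs from compound 3 by a single change: ethyl in place of hydrogen on a saturated chain carbon, two bonds along the chain from a carbonyl carbon. The same difference can be read as propanoyl to butylcarbonyl.

Within the data shown here, no measured step makes this change, so the evidence is indirect. The steps at the same oxygen are an at least 2.3-fold lower number from compound 1 to compound 2 (0.36 log units; beyond the scatter), then an at least 1.1-fold higher number from compound 2 to compound 3 (0.06 log units; that floor lies within the scatter), while a step that the two limits leave unreadable from compound 1 to compound 3. Among the measured compounds shown here, the only clear step is the one that brings in the dimethylamino end, and compound 4 has no such end. Compound 4 keeps the ester of compound 3, so it is expected to behave much like compound 3, and a report as a limit is quite likely. The expected step is a step that the limit leaves unreadable from compound 3 to compound 4, an estimate within the usual scatter. For compound 4 the estimated value is 14000 nM, with an expected range of 7000 nM to 30000 nM.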

Compound 4, half-maximal inhibitory concentration: > 10000 nM
Compound 4: no number, only a limit (the forecaster's own chance of this, stated with the estimate: 60%); the middle value does not contradict the limit.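

In this assay compound 4 is again reported only as a limit, so changing propanoyl to butylcarbonyl on this oxygen still gives no true number. Among these compounds, the steps that link compound 4 to compound 3 and to compound 1 cannot be read, as limits stand at both ends, and the one readable step is an at least 1.1-fold higher number from compound 2 to compound 4 (0.06 log units; that floor lies within the scatter), so its floor does not set these two compounds apart. The two esters, compound 3 and compound 4, also share the same reported limit: the limit of > 10000 nM in this assay, at which 2 of the 4 values shown sit.

As far as these compounds go, how far the true values of compound 3 and compound 4 lie beyond that limit stays open, and so does the size of any effect of the added ethyl. Also open, from the compounds shown here alone, is whether a longer chain on the ester, or a carboxylic acid in place of the ester, would give a true number at this oxygen.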